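The source may hold more compounds than are shown below. What is called first, only, known or untested is meant among the compounds shown, and "the series" means these compounds.

Measured so far:
Compound 1, `N#Cc1ccc(Nc2nccc(NCc3ccccn3)n2)cc1` — 8500 nM
Compound 2, `CN(C)c1ccnc(Nc2ccc(C#N)cc2)n1` — 34000 nM
Compound 3, `N#Cc1ccc(Nc2nccc(OCc3ccc(F)cc3)n2)cc1` — 81000 nM

In an ADME assay on MT4 cells (Homo sapiens) for cytotoxicity, read by MTT assay, with a stated time of 5 days (a lower number here means that less compound is tolerated, a higher number that more compound is tolerated), compound 1 gives 8500 nM, compound 2 gives 34000 nM and compound 3 gives 81000 nM. Compound 3 therefore stands at the highest number of the three, and its gaps to both compound 2 and compound 1 lie beyond the scatter, so it is the compound of which the most is tolerated in this assay.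

The next compound, compound 4, `N#Cc1ccc(Nc2nccc(OCc3ccccc3C#N)n2)cc1`, has not yet been measured in this assay. It differs from compound 3 in one place: 2-cyanophenyl in place of 4-fluorophenyl on a saturated chain carbon bound to an oxygen on an aromatic ring. This change sits on a saturated chain carbon bound to an oxygen on an aromatic ring. The rest of the structure of compound 3 is kept.

Going by the values given here, no step between two measured compounds that share this exchange is available, so the direction cannot be read from the data. A change of this kind, swapping one small aromatic substituent for another, is expected to leave the number close to that of compound 3, with any shift most likely within the scatter of this assay. Compound 4 is accordingly estimated at 60000 nM, with a range from 25000 nM to 150000 nM. The step this estimate implies, a 1.4-fold lower number from compound 3 to compound 4 (0.13 log units; within the scatter), is expected to be small.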

Compound 4, half-maximal cytotoxic concentration: 113000 nM
For compound 4 the middle estimate is 1.9-fold (0.27 log units) below the measured one; measured number inside the range.
By their numbers in this assay, from the lowest: compound 1; then compound 2; then compounds 3 and 4 (each within the scatter of the next).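

In this assay, going by these compounds alone, the exchange of 4-fluorophenyl for 2-cyanophenyl on a saturated chain carbon bound to an oxygen on an aromatic ring gives a 1.4-fold higher number from compound 3 to compound 4 (0.14 log units; within the scatter), the first step at this position that can be read. The earlier compounds shown here gave no direct reading of any single exchange, whereas this pair shows that, for these two aromatic groups, the change of group at this place leaves the tolerated concentration within the scatter, with the rest of the structure kept. No measurement is at hand that would explain this result.

The reading rests on one pair, both members of which carry a six-membered aromatic ring of carbon only at this place, so it cannot be extended to other kinds of group or to other substituents on that ring. On these data alone, whether a carboxylic acid or an amine on the ring, a saturated ring in place of the aromatic one, or a longer chain at this place would likewise leave the number within the scatter remains open.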